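The source may hold more compounds than are shown below. What is called first, only, known or untested is meant among the compounds shown, and "the series" means these compounds.

Measured so far:
- compound 1, `CCCCNc1nc(N)nc2c1CN(Cc1ccccc1)CC2`, in an assay on HEK293 cells for agonist activity at Toll-like receptor 8 (Homo sapiens), read by a luciferase reporter, with a stated time of 6 h (a lower number here means that less compound is needed, a higher number that more compound is needed for the effect), gives 0.06 uM
- compound 2, `CCCCNc1nc(N)nc2c1CN(C)CC2`, in this assay gives 0.03 uM
- compound 3, `CCCCNc1nc(N)nc2c1CN(C(=O)c1csc(C)n1)CC2`, in this assay gives 1.8 uM

All three share one core and a butylamino chain; they differ only in what sits on the ring nitrogen. Within the data shown here, compound 3, the only one carrying a carbonyl group there, stands at the highest number of the three, with a 30-fold higher number from compound 1 to compound 3 (1.48 log units; beyond the scatter) and a 60-fold higher number from compound 2 to compound 3 (1.78 log units; beyond the scatter). The two smaller substituents sit close together, as a 2.0-fold lower number from compound 1 to compound 2 (0.30 log units; within the scatter) shows.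

Compound 4, `CCCCNc1nc(N)nc2c1CN(C(=O)c1cc(C)on1)CC2`, keeps the carbonyl and changes only the ring attached to it: 5-methyl-1,2-oxazol-3-yl in place of 2-methyl-1,3-thiazol-4-yl on a carbonyl carbon. The measured steps all concern the move from a plain methyl or benzyl to the thiazolylcarbonyl, and they were large; none of them compares one five-membered aromatic ring with another on that carbonyl carbon. The counted difference is small, with the same number of heavy atoms, ring size and acceptor count, so in this assay compound 4 is expected to land close to compound 3, with a step of no change at the digits printed from compound 3 to compound 4 (within the scatter) and no clear direction beyond the scatter. The estimate for compound 4 is 1.8 uM, within 0.6 uM to 5.4 uM.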

Compound 4, minimum effective concentration: 0.4 uM
The estimate for compound 4 lay 4.5-fold (0.65 log units) above the measured number; the measured number lies below the stated range.
By their numbers in this assay, from the lowest: compounds 2 and 1 (each within the scatter of the next); then compound 4; then compound 3.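

In this assay the ring on the carbonyl carbon proves to matter in its own right: keeping the carbonyl and swapping 2-methyl-1,3-thiazol-4-yl for 5-methyl-1,2-oxazol-3-yl gives a 4.5-fold lower number from compound 3 to compound 4 (0.65 log units; beyond the scatter) even though the two groups have the same counts of heavy atoms and hydrogen-bond acceptors. Groups that look alike by these counts are therefore not interchangeable at this position. The change closes only part of the gap to the compounds without a carbonyl, as a 13-fold higher number from compound 2 to compound 4 (1.12 log units; beyond the scatter) and a 6.7-fold higher number from compound 1 to compound 4 (0.82 log units; beyond the scatter) show, so both carbonyl compounds still need more compound than either the methyl or the benzyl compound. Nothing measured here explains why the two rings differ.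

Still open, as far as these compounds go, is whether the carbonyl or the ring accounts for the larger part of the gap, which a 5-methyl-1,2-oxazol-3-ylmethyl group on the ring nitrogen, with a plain carbon in place of the carbonyl, could help to separate. From the compounds shown here alone, it is also open how a plain phenyl ring on the carbonyl carbon would compare, and whether the same ring swap gives a similar step with a pentyl chain in place of butyl.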